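The source may report more compounds than this note shows. Statements on the series, on what has been measured and on what is new or still open speak of the compounds shown alone.

Compound 1 `Cc1ccccc1CSc1nnc(-c2ccc3c(c2)OCCO3)o1` and compound 2 `Clc1ccccc1CSc1nnc(-c2ccc3c(c2)OCCO3)o1` share one core and differ in a single group on the outer ring. In a functional assay on SW 1116 cells (Homo sapiens) for antiproliferative activity, read by MTT assay, with a stated time of 48 h (a lower number here means a stronger inhibitor, a higher number a weaker inhibitor), compound 1 gives 23900 nM, and compound 2 gives 29500 nM. The step of a 1.2-fold higher number from compound 1 to compound 2 (0.09 log units; within the scatter) lies within the scatter, so compound 2 stands level with compound 1 among these two numbers. Compound 3 `O=[N+]([O-])c1ccccc1CSc1nnc(-c2ccc3c(c2)OCCO3)o1` keeps the core and carries the change (nitro in place of chloro on an aromatic carbon). Within the data shown here, the only step that bears on this exchange is a 1.2-fold higher number from compound 1 to compound 2 (0.09 log units; within the scatter), and little change is expected because a 1.2-fold higher number from compound 1 to compound 2 (0.09 log units; within the scatter) stayed within the scatter. The estimated step of a 1.0-fold higher number from compound 2 to compound 3 (0.01 log units; within the scatter) is therefore expected to be small. Compound 3 is expected to give 30000 nM, between 14000 nM and 65000 nM.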

Compound 3, half-maximal inhibitory concentration: 20800 nM
For compound 3 the middle estimate is 1.4-fold (0.16 log units) above the measured one, within the range that was stated.
By their numbers in this assay, from the lowest: compounds 3, 1 and 2 (each within the scatter of the next).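

On the outer ring, at the place ortho to a large group, nitro has more heavy atoms than chloro and two hydrogen-bond acceptors where chloro has none, yet the numbers in this assay stay level (a 1.4-fold lower number from compound 2 to compound 3 (0.15 log units; within the scatter)) and (a 1.1-fold lower number from compound 1 to compound 3 (0.06 log units; within the scatter)). Methyl, chloro and nitro, three quite different groups, can therefore be exchanged here without a step that leaves the scatter. No separate measurement is available to explain this. From the compounds shown here alone, whether an amine or a carboxylic acid at this place would move the number beyond the scatter remains open, as does the effect of any of these groups elsewhere on the ring.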